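Amino in place of hydrogen: compound 2 to compound 3

A few compounds are considered here, and "the series" means these few. Any claim that something is new, unique, unknown or untested is made for them only; others in the source may bear on it.

Measured so far in a functional assay on HEp-2 cells (Homo sapiens) for cytotoxicity, read by MTT assay, with a stated time of 24 h (a higher number here means a weaker inhibitor, a lower number a stronger inhibitor), for this series:
- compound 1 `COc1cc(C)cc2c1C(=O)C=C(c1c(C)cc3c(c1OC)C(=O)C(Nc1ccc4ccccc4c1)=CC3=O)C2=O` gives 2040 nM
- compound 2 `COc1cc(C)cc2c1C(=O)C=C(c1c(C)cc3c(c1OC)C(=O)C(N)=CC3=O)C2=O` gives 3510 nM

Compound 2 stands within the scatter of compound 1, so these two values set no order. Compound 3 `COc1cc(C)cc2c1C(=O)C(N)=C(c1c(C)cc3c(c1OC)C(=O)C(N)=CC3=O)C2=O` has amino in place of hydrogen on a double-bonded ring carbon. Going by the values given here, the only measured step (a 1.7-fold higher number from compound 1 to compound 2 (0.24 log units; within the scatter)) is a change on an amine nitrogen, from naphthalen-2-yl to hydrogen, and it stays within the scatter. Among the compounds with values here, it bears only loosely on the new change, since no measured step places amino on a ring carbon. From the compounds shown here alone, the direction therefore stays open, and no step beyond the scatter is expected in this assay for now. The estimated step is small (a 1.2-fold lower number from compound 2 to compound 3 (0.07 log units; within the scatter)). Compound 3 is estimated at 3000 nM (expected range 1200 nM to 7500 nM).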

Compound 3, half-maximal inhibitory concentration: 2340 nM
Beside the measured number, compound 3's estimate is 1.3-fold (0.11 log units) above it; the range from low to high includes it.
By their numbers in this assay, from the lowest: compounds 1, 3 and 2 (each within the scatter of the next).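

In this assay, amino in place of hydrogen on a double-bonded ring carbon, next to the ring atom that bears a large group, gives a 1.5-fold lower number from compound 2 to compound 3 (0.18 log units; within the scatter). This position, which carries hydrogen in compound 1 and compound 2, therefore accepts amino without a step beyond the scatter, as does the earlier change on the amine nitrogen, a 1.7-fold higher number from compound 1 to compound 2 (0.24 log units; within the scatter). No supporting data are available to explain this result.

From the compounds shown here alone, whether a group such as a carboxylic acid, a hydroxyl or a longer alkyl chain at this same ring carbon would give a step beyond the scatter remains open. Also open, going by these compounds, is whether amino at this position would give a similar step with naphthalen-2-yl on the amine nitrogen, as in compound 1.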